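The compounds below may be only part of what the source reports. "The series", "measured", "known", "first", "only" and "open" are said of these compounds alone.

The measured compounds:
Compound 1, `N#Cc1ccc2nc(-c3ccc(-c4ccccc4F)cc3)[nH]c2c1`, in an assay on isolated protein for inhibition of acyl-CoA desaturase 1 (Rattus norvegicus) (on this read-out higher numbers stand for weaker inhibition and lower numbers for stronger inhibition), compound 1 sits at the limit > 20000 nM.
Compound 2, `Cc1ccc(-c2ccc(-c3nc4ccc(S(C)(=O)=O)cc4[nH]3)cc2)cc1`, in this assay compound 2 sits at the limit > 20000 nM.
Compound 3, `Cc1cccc(-c2ccc(-c3nc4ccc(S(C)(=O)=O)cc4[nH]3)cc2)c1`, in this assay compound 3 gives 319 nM.

For the measured compounds named here, compound 3 thus holds the only real number in this assay; the two other values are limits, as the limit of > 20000 nM in this assay, at which 2 of the 3 values shown sit, states. Going by the values given here, the one measured step, an at least 62-fold lower number from compound 2 to compound 3 (1.79 log units; beyond the scatter), is the move to a 3-methylphenyl group, and it is large.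

Compound 4, `Cc1ccsc1-c1ccc(-c2nc3ccc(S(C)(=O)=O)cc3[nH]2)cc1`, differs from compound 3 by 3-methylthiophen-2-yl in place of 3-methylphenyl on an aromatic carbon. Among the compounds with values here, no measured step bears directly on this change; the step from compound 2 to compound 3 concerns only where the methyl group sits on a six-membered ring, not the swap of that ring for a five-membered one. The expectation therefore rests on compound 3 alone, and a step of about a 1.6-fold higher number from compound 3 to compound 4 (0.20 log units; within the scatter) is expected, with the direction uncertain. Compound 4 is estimated to give 500 nM in this assay, within a range from 150 nM to 2500 nM.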

Compound 4, half-maximal inhibitory concentration: 472 nM
Compound 4: the middle estimate sits 1.1-fold (0.03 log units) above what was measured, within the range that was stated.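

In this assay, the six-membered carbon ring at this position gives way to a five-membered ring holding sulfur with no change beyond the scatter: a 1.5-fold higher number from compound 3 to compound 4 (0.17 log units; within the scatter). The large difference from the 4-methylphenyl group of compound 2 therefore also holds for the 3-methylthiophen-2-yl group of compound 4, with an at least 42-fold lower number from compound 2 to compound 4 (1.62 log units; beyond the scatter), so it is not confined to the 3-methylphenyl group of compound 3. Compound 2 stands at a limit and not at a number, so this step is only a bound: the limit of > 20000 nM in this assay, at which 2 of the 4 values shown sit.

The compounds shown leave open what a 3-methylthiophen-2-yl group would give with its methyl replaced by hydrogen, an ethyl group or a chlorine atom. They also leave open whether a pyridine ring at this position would fit with the two rings seen here.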